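Adding Two Methyl Groups to the Cyclohexanol of Compound 2

The source may report more compounds than this note shows. Statements on the series, on what has been measured and on what is new or still open speak of the compounds shown alone.

Of the compounds shown here, three share one core and have been tested in an assay on isolated protein for inhibition of protein kinase C theta type (Homo sapiens), read by TR-FRET, with a stated time of 2 h; on this read-out higher numbers stand for weaker inhibition and lower numbers for stronger inhibition. Compound 1, `N#Cc1cnc(NCc2ccccc2C(F)(F)F)cc1N[C@H]1CC[C@@H](O)CC1`, gives 140 nM. Compound 3, `N#Cc1cnc(NCc2cncnc2OCC(F)F)cc1N[C@H]1CC[C@@H](O)CC1`, gives 90 nM. Compound 2, `N#Cc1cnc(NCc2cnccc2C(F)(F)F)cc1N[C@H]1CC[C@H](O)CC1`, gives 350 nM, the highest number of the three; the gaps to compound 1 and to compound 3 both lie beyond the usual scatter, so compound 2 is the weakest inhibitor among the measured set.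

Compound 4, `CC1(C)C[C@@H](Nc2cc(NCc3cnccc3C(F)(F)F)ncc2C#N)CC[C@H]1O`, is not yet measured. It differs from compound 2 in one place: 4-hydroxy-3,3-dimethylcyclohexyl in place of 4-hydroxycyclohexyl on a nitrogen on an aromatic ring. Among the compounds with values here, the hydroxyl and the cyclohexane ring remain, and the only addition is the pair of methyl groups on the ring.

Within the data shown here, no pair of measured compounds shows this change, so no step for it is known. Among the measured compounds shown here, the account therefore rests on the single starting value of compound 2 and on the small size of the change. A modest step is expected in this assay, more likely toward a lower number than a higher one, but not far beyond the scatter. Compound 4 is estimated at 170 nM, within 50 nM to 550 nM, which would mean a step of a 2.1-fold lower number from compound 2 to compound 4 (0.31 log units; beyond the scatter) in this assay.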

Compound 4, half-maximal inhibitory concentration: 120 nM
Compound 4: the middle estimate sits 1.4-fold (0.15 log units) above what was measured, and the stated range covers the measured number.
By their numbers in this assay, from the lowest: compounds 3, 4 and 1 (each within the scatter of the next); then compound 2.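

In this assay, within the data shown here, the change from (4-hydroxycyclohexyl)amino to (4-hydroxy-3,3-dimethylcyclohexyl)amino gives a 2.9-fold lower number from compound 2 to compound 4 (0.46 log units; beyond the scatter), the first step between two compounds that differ in one place. It shows that this position, on a nitrogen on an aromatic ring, accepts a larger 4-hydroxy-3,3-dimethylcyclohexyl group with no loss of inhibition and a modest gain that lies beyond the usual scatter, while the hydroxyl and the ring stay in place and the rest of compound 2 is unchanged. Nothing in the available data accounts for this gain, so the step stands as an observation without an explanation.

Going by these compounds, the step is known on a single background, so it remains open whether the same pair of methyl groups would lower the number to a similar extent on the cores of compound 1 and compound 3, which carry other groups elsewhere in the molecule. On these data alone, it is also open whether a single methyl group on the ring would be enough, and how an amine or a methoxy group in place of the hydroxyl would fare at this position.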